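Piperidin-4-yl in place of 3-amino-3-methylbutyl

The source may report more compounds than this note shows. Statements on the series, on what has been measured and on what is new or still open speak of the compounds shown alone.

- compound 1 `c1cc([C@H]2CC[C@]3(CC2)OOC2(O3)C3CC4CC(C3)CC2C4)ccc1OCCOC1CCNCC1`: 633 nM
- compound 2 `CC(C)(O)CNCCCOc1ccc([C@H]2CC[C@]3(CC2)OOC2(O3)C3CC4CC(C3)CC2C4)cc1`: 1210 nM
- compound 3 `CC(C)(N)CCOc1ccc([C@H]2CC[C@]3(CC2)OOC2(O3)C3CC4CC(C3)CC2C4)cc1`: 1050 nM

These values come from an ADME assay on the whole organism (strain FVB) for pharmacokinetics, with Mus musculus as the target, read by LC-MS, at a dose of 30 mg/kg by the oral route; on this read-out higher numbers stand for higher exposure at the dose given and lower numbers for lower exposure. Compound 3 stands level with the other two, since neither of its steps leaves the scatter: a 1.7-fold higher number from compound 1 to compound 3 (0.22 log units; within the scatter) and a 1.2-fold lower number from compound 2 to compound 3 (0.06 log units; within the scatter). The remaining step is also small: a 1.9-fold higher number from compound 1 to compound 2 (0.28 log units; within the scatter).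

The next compound is compound 4 `c1cc([C@H]2CC[C@]3(CC2)OOC2(O3)C3CC4CC(C3)CC2C4)ccc1OC1CCNCC1`. It differs from compound 3 as follows: piperidin-4-yl in place of 3-amino-3-methylbutyl on an oxygen on an aromatic ring. In words, piperidin-4-yl stands in place of 3-amino-3-methylbutyl on an oxygen on an aromatic ring.

Within the data shown here, no measured step makes this exact change. The closest is the step between compound 1 and compound 3, where (piperidin-4-yl)oxy gives way to 1-amino-1-methylethyl on a saturated chain carbon, and that step stayed within the scatter. All three measured steps are small, so no shift beyond the scatter is expected. The expected step is a 1.3-fold lower number from compound 3 to compound 4 (0.12 log units; within the scatter). For compound 4 the estimated value is 800 nM, with an expected range from 300 nM to 2100 nM.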

Compound 4, maximal plasma concentration: 810 nM
The estimate for compound 4 lay 1.0-fold (0.01 log units) below the measured number; measured number inside the range.
By their numbers in this assay, from the lowest: compounds 1, 4, 3 and 2 (each within the scatter of the next).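

In this assay, piperidin-4-yl on an oxygen on an aromatic ring stands level with the open-chain 3-amino-3-methylbutyl, which has the same heavy-atom count: a 1.3-fold lower number from compound 3 to compound 4 (0.11 log units; within the scatter). The two longer groups give the same picture, with 3-((2-hydroxy-2-methylpropyl)amino)propyl leaving in a 1.5-fold lower number from compound 2 to compound 4 (0.17 log units; within the scatter) and 2-((piperidin-4-yl)oxy)ethyl leaving in a 1.3-fold higher number from compound 1 to compound 4 (0.11 log units; within the scatter), so neither the ring nor the longer chains separate these four compounds at this position. Nothing measured here offers an explanation for this flat result.

From the compounds shown here alone, all four compounds carry an amine in this group, so it remains open whether a carboxylic acid or an amide on this oxygen would move the number beyond the scatter. Going by these compounds, the effect of a substituent on the piperidine nitrogen also remains open.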